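Swapping tert-butyl for methyl on compound 2

The source may report more compounds than this note shows. Statements on the series, on what has been measured and on what is new or still open speak of the compounds shown alone.

In a functional assay on A549 cells (Homo sapiens) for cytotoxicity, read by MTT assay, with a stated time of 72 h (a lower number here means a stronger inhibitor, a higher number a weaker inhibitor), compound 1 `CN(C)Cc1ccc2nc(NC(=O)N/N=C3\C(=O)Nc4ccc(Cl)cc43)sc2c1` gives 3180 nM as its reading, and compound 2 `CN(C)Cc1ccc2nc(NC(=O)N/N=C/c3cn(Cc4ccc(C(C)(C)C)cc4)c4ccccc34)sc2c1` gives 1850 nM as its reading. These two values lie within the usual scatter of repeated measurements, so the numbers cannot tell compound 2 and compound 1 apart, even though their structures differ in more than one place.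

Next comes compound 3 `Cc1ccc(Cn2cc(/C=N/NC(=O)Nc3nc4ccc(CN(C)C)cc4s3)c3ccccc32)cc1`, which differs from compound 2 in a single group: methyl in place of tert-butyl on an aromatic carbon (methyl in place of tert-butyl on an aromatic carbon, para to a large group). Cut one bond further out, the same change reads 4-(tert-butyl)benzyl to 4-methylbenzyl.

Within the data shown here, no measured pair in this small set shows what such a swap does, so the expectation rests only on compound 2, with its 1850 nM as the starting point. No step beyond the scatter is expected in this assay here, and the estimated step is a 1.3-fold higher number from compound 2 to compound 3 (0.11 log units; within the scatter) as a cautious working figure. For compound 3 the estimated value is 2400 nM as the middle, with an expected range from 900 nM to 6500 nM as the likely span.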

Compound 3, half-maximal inhibitory concentration: 1600 nM
Beside the measured number, compound 3's estimate is 1.5-fold (0.18 log units) above it; measured number inside the range.
By their numbers in this assay, from the lowest: compounds 3, 2 and 1 (each within the scatter of the next).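

In this assay, methyl in place of tert-butyl on the aromatic carbon, para to a large group, gives a 1.2-fold lower number from compound 2 to compound 3 (0.06 log units; within the scatter). Among these compounds, this is the first pair in the set that differs in one place only, and it shows that the assay cannot tell these two groups apart at this position, even though the 4-(tert-butyl)benzyl group carries 4 heavy atoms in its tert-butyl end and the 4-methylbenzyl group only 1 in its methyl end. Nothing measured here offers an explanation for this result.

Going by these compounds, both groups are small hydrocarbons without hydrogen-bond donors or acceptors or a net charge, so it remains open whether a group of a different kind at this same carbon, such as an amine, a carboxylic acid or a longer chain ending in a hydroxyl group, would give a clearly different reading, and whether plain hydrogen there would read the same. A single pair also leaves open whether this swap would read alike on a different core, such as the core of compound 1.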